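Hydroxy in place of hydrogen at the end of a chain

A few compounds are considered here, and "the series" means these few. Any claim that something is new, unique, unknown or untested is made for them only; others in the source may bear on it.

Of the compounds shown here, three in this set have been tested in an assay on NK92 cells for inhibition of interleukin-2 (Homo sapiens), read by AlphaScreen, with stated times of 30 min and 1 h; a lower number here means a stronger inhibitor, a higher number a weaker inhibitor. Compound 1 `Cn1c(Cc2nn(CCC=O)c(=O)c3ccccc23)nnc1SCC(=O)Nc1ccc(Cl)cc1Cl` returns only a limit of the assay, > 30000 nM. Compound 2 `Cn1c(Cc2nn(CCC(=O)O)c(=O)c3ccccc23)nnc1SCC(=O)Nc1ccc(Cl)cc1Cl` likewise returns a limit, > 30000 nM. The two differ in one place, (hydroxy in place of hydrogen on a carbonyl carbon). The step that the two limits leave unreadable from compound 1 to compound 2 therefore gives no readable size, because the limit of > 30000 nM in this assay, at which 2 of the 3 values shown sit, holds both ends of it.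

Going by the values given here, compound 3 `Cn1c(Cc2nn(CCC=O)c(=O)c3ccccc23)nnc1SCCCCCCCC(=O)Nc1ccc(Cl)cc1Cl` is the only member of the set with a measured number. It differs from compound 1 in more than one place, and how the two cores differ is not broken down here. In this assay compound 3 gives 21900 nM. That number is a weak one, not far from where the other two values stop being read.

Compound 4 `Cn1c(Cc2nn(CCC(=O)O)c(=O)c3ccccc23)nnc1SCCCCCCCC(=O)Nc1ccc(Cl)cc1Cl` has not yet been measured. It stands to compound 3 as compound 2 stands to compound 1, with the same change at the same place: hydroxy in place of hydrogen on a carbonyl carbon. Among the compounds with values here, the one measured instance of this change offers no size to carry over, since both of its ends are limits. What remains is that compound 3 is itself a weak inhibitor near the limit, so compound 4 is expected to be weak as well, with a step of a 1.3-fold higher number from compound 3 to compound 4 (0.11 log units; within the scatter) that is more likely to push it to the limit than away from it. Compound 4 is therefore estimated at 28000 nM, between 12000 nM and 60000 nM, with a real chance that the assay reports only a limit.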

Compound 4, half-maximal inhibitory concentration: 30000 nM
Beside the measured number, compound 4's estimate is 1.1-fold (0.03 log units) below it; the range from low to high includes it.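

In this assay, hydroxy in place of hydrogen on a carbonyl carbon, carried on the core of compound 3, appears as a 1.4-fold higher number from compound 3 to compound 4 (0.14 log units; within the scatter). Going by these compounds alone, this is the only readable instance of the formyl to carboxy change in the set, and it shows that on this one core the 2-formylethyl and 2-carboxyethyl compounds cannot be told apart, with both numbers lying in the weak part of the range that this assay reads. It does not show that the change behaves alike on different cores, because the step on the core of compound 1 cannot be read, with compound 1 and compound 2 each returning only a limit of the assay: the limit of > 30000 nM in this assay, at which 2 of the 4 values shown sit.

The compounds shown leave open whether a primary amide, a methyl ester or an amine in place of the carboxy at the end of this chain would read any differently from compound 3 and compound 4 in this assay. They also leave open whether the same change would stay within the scatter on a core with a much lower number, where a shift in either direction could be read in full.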